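The source may report more compounds than this note shows. Statements on the series, on what has been measured and on what is new or still open speak of the compounds shown alone.

Of the compounds shown here, three built on one shared core have been tested in a functional assay on MCF7 cells (Homo sapiens) for inhibition, read by sulforhodamine B assay, with a stated time of 48 h, tested at 50 uM; a lower number here means less inhibition of growth, a higher number more inhibition of growth at the concentration tested. Compound 1 `COc1ccc([C@@H]2C/C(=N/OCc3cn(-c4ccccc4CO)nn3)c3cc(CC=C(C)C)c(OC)cc3O2)cc1` gives 100%, the highest of the three numbers. Compound 2 `COc1cc2c(cc1CC=C(C)C)C(=O)C[C@@H](c1ccc(Oc3ccccc3)cc1)O2` gives 69%, and compound 3 `CCOc1ccc([C@@H]2CC(=O)c3cc(CC=C(C)C)c(OC)cc3O2)cc1` gives 57%; both of these lie beyond the scatter from compound 1. Going by the values given here, the only measured pair that differs in a single place shows a number 12 percentage points lower from compound 2 to compound 3 (beyond the scatter), a modest drop that comes with ethyl in place of phenyl on an oxygen on an aromatic ring.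

Compound 4 `COc1ccc([C@@H]2C/C(=N/OCc3cn(-c4ccc(NC(C)=O)cc4)nn3)c3cc(CC=C(C)C)c(OC)cc3O2)cc1` has not yet been measured. It differs from compound 1 at the aromatic nitrogen of the five-membered ring that holds three nitrogens: 4-acetamidophenyl in place of 2-(hydroxymethyl)phenyl on an aromatic nitrogen. Among the compounds with values here, no measured step touches this part of the molecule; the step from compound 2 to compound 3 concerns a group on an oxygen elsewhere on the core, so it offers no direct guide to the size or direction of the change here. Compound 1 already sits at complete inhibition, so with nothing pointing to a loss, compound 4 is expected to remain strongly inhibitory, with room only for a small decrease. Compound 4 is estimated at 90%, with a range from 70% to 100%. This estimate corresponds to an expected step of a number 10 percentage points lower from compound 1 to compound 4 (within the scatter).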

Compound 4, percent growth inhibition at one concentration: 0%
The estimate for compound 4 lay 90 percentage points above the measured number; measured number below the stated range.
By their numbers in this assay, from the lowest: compound 4; then compound 3; then compound 2; then compound 1.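

The group on the aromatic nitrogen of the five-membered ring with 3 nitrogen proves decisive in this assay: 4-acetamidophenyl in place of 2-(hydroxymethyl)phenyl comes with a number 100 percentage points lower from compound 1 to compound 4 (beyond the scatter), a large step from a single change. Going by these compounds alone, compounds 2 and 3 carry no such ring, and their one step, a number 12 percentage points lower from compound 2 to compound 3 (beyond the scatter), lies on an oxygen elsewhere, so only this new pair reveals how much this position can matter. The two groups match in their counts of hydrogen-bond donors and acceptors and in having no net charge, and they share a six-membered aromatic ring of carbon, yet no measurement at hand explains the difference in growth inhibition.

The two groups differ both in what is attached to the phenyl ring and in where it sits, and the compounds shown do not separate these two changes. They also leave open how compound 1's core would behave with a plain phenyl at this nitrogen, or with a phenyl carrying an amine or a carboxylic acid.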